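Swapping bromomethyl for 1-chloroethyl in compound 2

A few compounds are considered here, and "the series" means these few. Any claim that something is new, unique, unknown or untested is made for them only; others in the source may bear on it.

Measured in a functional assay on CCRF-CEM cells (Homo sapiens) for antiproliferative activity, read by trypan blue exclusion, with a stated time of 72 h; a higher number here means a weaker inhibitor, a lower number a stronger inhibitor:
- Compound 1 `Cc1ccc(C(=O)NC(N)=O)cc1NC(=O)CBr`: 4280 nM
- Compound 2 `NC(=O)NC(=O)c1ccc(Cl)c(NC(=O)CBr)c1`: 2910 nM
- Compound 3 `COc1ccc(C(=O)NC(N)=O)cc1NC(=O)CBr`: 1880 nM

Compound 2 gives 2910 nM in this assay, and this number stands within the scatter of both other values. The two steps that show this are a 1.5-fold lower number from compound 1 to compound 2 (0.17 log units; within the scatter) and a 1.5-fold lower number from compound 2 to compound 3 (0.19 log units; within the scatter). Among the compounds with values here, the only step among the three that goes beyond the scatter is a 2.3-fold lower number from compound 1 to compound 3 (0.36 log units; beyond the scatter). All three steps exchange a group on an aromatic carbon, and the bromomethyl stays unchanged throughout.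

Compound 4 `CC(Cl)C(=O)Nc1cc(C(=O)NC(N)=O)ccc1Cl` keeps the aromatic chloro of compound 2 and changes the other end instead: 1-chloroethyl in place of bromomethyl on a carbonyl carbon. This puts 1-chloroethyl in place of bromomethyl on a carbonyl carbon. Within the data shown here, no measured compound alters this group, so the three steps serve only as a rough yardstick of size. A step somewhat larger than those is expected, probably towards a higher number, but the measured compounds cannot settle the direction. The expected change is a 2.1-fold higher number from compound 2 to compound 4 (0.31 log units; beyond the scatter). For compound 4 the estimated value is 6000 nM, with an expected range of 1800 nM to 20000 nM.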

Compound 4, half-maximal inhibitory concentration: > 20000 nM
Compound 4 was reported as a limit; the forecaster's own chance of this, stated with the estimate: 10%; middle value at least 3.3-fold (0.52 log units) from the limit.
By their numbers in this assay, from the lowest: compounds 3, 2 and 1 (each within the scatter of the next, the first and the last beyond it). At a limit, above all of these: compound 4.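

In this assay compound 4 gives > 20000 nM, which is a limit and not a number. Within the data shown here, the step to it is an at least 6.8-fold higher number from compound 2 to compound 4 (0.83 log units; beyond the scatter), and that minimum already exceeds the largest step among the earlier compounds, a 2.3-fold lower number from compound 1 to compound 3 (0.36 log units; beyond the scatter), so the group on the carbonyl carbon can shift this read-out further than any of the exchanges on the aromatic carbon did. Compound 4 alone reaches that limit, which marks 1-chloroethyl as a poor replacement for bromomethyl here when the aromatic chloro stays in place: the limit of > 20000 nM in this assay, at which 1 of the 4 values shown sits.

The exchange alters the halogen and the carbon count together, so the compounds shown cannot say which of the two accounts for the weaker result; chloromethyl or 1-bromoethyl on the same carbonyl carbon would pull the two apart. Going by these compounds, it also stays open whether 1-chloroethyl would give the same kind of result alongside the aromatic methyl of compound 1 or the methoxy of compound 3, and how far beyond the limit the true value of compound 4 lies.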